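Swapping the aryl group on the aromatic nitrogen

This account rests on a few compounds, and the source may have more. Where it says the series, first, only, none or still open, it means among the compounds named here.

Measured so far:
compound 1 `Cc1cccc(-n2cc(COc3cccc(NC(=O)Nc4ccc(Cl)c(C(F)(F)F)c4)c3)nn2)c1`: 7270 nM
compound 2 `CCc1ccccc1-n1cc(COc2cccc(NC(=O)Nc3ccc(Cl)c(C(F)(F)F)c3)c2)nn1`: 3530 nM

Both compounds share one core and differ only in the aryl group carried on an aromatic nitrogen. In a functional assay on HepG2 cells (Homo sapiens) for inhibition, read by MTT assay, with a stated time of 72 h (on this read-out lower numbers stand for stronger inhibition and higher numbers for weaker inhibition), compound 1 gives 7270 nM, and compound 2 gives 3530 nM. Among the compounds with values here, the one step on record, a 2.1-fold lower number from compound 1 to compound 2 (0.31 log units; beyond the scatter), shows that exchanging this aryl group can move the number by a modest amount. Within the data shown here, compound 2 therefore stands with the lowest number of the two, with compound 1 as its only neighbour.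

Compound 3 `N#Cc1ccc(-n2cc(COc3cccc(NC(=O)Nc4ccc(Cl)c(C(F)(F)F)c4)c3)nn2)cc1` is the next variation at the same place: 4-cyanophenyl in place of 2-ethylphenyl on an aromatic nitrogen. Among the measured compounds shown here, no measured step covers this particular exchange, so the only guide is the size of the step from compound 1 to compound 2, which was modest. On that basis the number for compound 3 in this assay is expected to land near that of compound 2, with a step of a 1.4-fold higher number from compound 2 to compound 3 (0.15 log units; within the scatter), and the estimate is 5000 nM, within a range from 1500 nM to 16000 nM.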

Compound 3, half-maximal inhibitory concentration: 2980 nM
For compound 3 the middle estimate is 1.7-fold (0.22 log units) above the measured one; measured number inside the range.
By their numbers in this assay, from the lowest: compounds 3 and 2 (each within the scatter of the next); then compound 1.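

In this assay the exchange of 2-ethylphenyl for 4-cyanophenyl gives a 1.2-fold lower number from compound 2 to compound 3 (0.07 log units; within the scatter) and so does not separate these two groups, although the entering group brings a nitrile and a hydrogen-bond acceptor that the leaving group lacks. Set against the 3-methylphenyl group, the same 4-cyanophenyl group gives a 2.4-fold lower number from compound 1 to compound 3 (0.39 log units; beyond the scatter) and matches the earlier step in direction, which leaves compound 1 as the weakest of the three, with compound 2 and compound 3 level with each other. Nothing available explains why the 3-methylphenyl group stands apart from the other two.

Still open, on these data alone, is how this position would respond to an amine or a carboxylic acid on the phenyl ring, or to a longer chain in place of the ring. As far as these compounds go, it is also open whether the gap follows the kind of group on the ring or where it sits, as 3-methylphenyl, 2-ethylphenyl and 4-cyanophenyl differ in both at once.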